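Methyl on the fused ring of compound 1

The compounds below may be only part of what the source reports. "The series", "measured", "known", "first", "only" and "open" are said of these compounds alone.

Compound 1 `Cc1ccc(-c2cn(/N=C/c3cc4ccccc4nc3Cl)c(N)n2)cc1` stands at the edge of a functional assay on HCT-116 cells (Homo sapiens) for cytotoxicity, read by MTT assay, with a stated time of 48 h; on this read-out higher numbers stand for weaker inhibition and lower numbers for stronger inhibition: in this assay compound 1 gives > 50000 nM, a limit and not a number. Compound 2 `Nc1nc(-c2ccc(Cl)cc2)cn1/N=C/c1cc2ccccc2nc1Cl` likewise reaches only a limit, giving > 50000 nM in this assay. Between them lies a step that the two limits leave unreadable from compound 1 to compound 2, unreadable because the limit of > 50000 nM in this assay, at which 2 of the 2 values shown sit, holds both values. Compound 3 `Cc1ccc(-c2cn(/N=C/c3cc4cc(C)ccc4nc3Cl)c(N)n2)cc1` differs from compound 1 by methyl in place of hydrogen on an aromatic carbon. Within the data shown here, no measured step bears on this change, so no shift beyond the scatter is expected, a number no higher from compound 1 to compound 3 (the limit leaves the size open). Compound 3 is estimated at 50000 nM, within 20000 nM to 150000 nM, most probably again a limit.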

Compound 3, half-maximal inhibitory concentration: 39600 nM
Beside the measured number, compound 3's estimate is 1.3-fold (0.10 log units) above it; low and high end bracket the measured number.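

Methyl in place of hydrogen on an aromatic carbon of the fused system gives an at least 1.2-fold lower number from compound 1 to compound 3 (0.10 log units; that floor lies within the scatter) in this assay. Among these compounds, this is the first measured number, so the place tolerates methyl without loss of a readable value, yet the printed floor does not separate the change from scatter. Most of the series still rests on a limit: the limit of > 50000 nM in this assay, at which 2 of the 3 values shown sit.

As far as these compounds go, the true size of this step remains open. Also open, from the compounds shown here alone, is whether an amine or a longer chain at this place would shift the number beyond the scatter.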